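Halogenated phenyl in place of trifluoromethylphenyl on a shared core

The compounds below may be only part of what the source reports. "The series", "measured", "known", "first", "only" and "open" are said of these compounds alone.

compound 1 `CC/C(=C(/c1ccc(/C=C/C(=O)O)cc1)c1cc2ccccc2[nH]1)c1cccc(C)c1`: 140 nM
compound 2 `CC/C(=C(/c1ccc(/C=C/C(=O)O)cc1)c1cc2ccccc2[nH]1)c1ccc(C(F)(F)F)cc1`: 139 nM

In a functional assay on MCF7 cells (Homo sapiens) for inhibition (on this read-out higher numbers stand for weaker inhibition and lower numbers for stronger inhibition), compound 1 gives 140 nM and compound 2 gives 139 nM, so the two numbers are within the scatter of each other. Compound 3 `CC/C(=C(/c1ccc(/C=C/C(=O)O)cc1)c1cc2ccccc2[nH]1)c1ccc(F)cc1Cl` differs from compound 2 by 2-chloro-4-fluorophenyl in place of 4-(trifluoromethyl)phenyl on a double-bonded chain carbon bound to a double-bonded chain carbon and a saturated chain carbon. The one measured step at this place, a 1.0-fold lower number from compound 1 to compound 2 (0.00 log units; within the scatter), was within the scatter, so a change of aryl group there has not shown an effect beyond scatter. Compound 3 is therefore expected to show a 1.0-fold higher number from compound 2 to compound 3 (0.00 log units; within the scatter), no step beyond the scatter. The estimate for compound 3 is 140 nM, expected between 60 nM and 330 nM.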

Compound 3, half-maximal inhibitory concentration: 39 nM
Estimate against measurement, compound 3: 3.6-fold (0.56 log units) above; the whole stated range lies above it.
By their numbers in this assay, from the lowest: compound 3; then compounds 2 and 1 (each within the scatter of the next).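

In this assay the aryl group on a double-bonded chain carbon bound to a double-bonded chain carbon and a saturated chain carbon now proves able to shift the read-out: 2-chloro-4-fluorophenyl gives a 3.6-fold lower number from compound 2 to compound 3 (0.55 log units; beyond the scatter) and a 3.6-fold lower number from compound 1 to compound 3 (0.56 log units; beyond the scatter) while 3-methylphenyl and 4-(trifluoromethyl)phenyl had stayed within the scatter of each other. Nothing measured here explains these steps. The compounds shown leave open whether the chlorine or the fluorine of the entering group carries the steps, or both together, a question that 2-chlorophenyl and 4-fluorophenyl at this place would address.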